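A few compounds are considered here, and "the series" means these few. Any claim that something is new, unique, unknown or untested is made for them only; others in the source may bear on it.

Measured so far in an assay on isolated protein for inhibition of sterol O-acyltransferase 1 (Rattus norvegicus); on this read-out higher numbers stand for weaker inhibition and lower numbers for stronger inhibition: compound 1 `CCCCCCCCCCN(CCCCCCCCCC)C(=O)Nc1ccc(C)cc1C` gives 0.28 ug/mL; compound 2 `Cc1cc(C)c(NC(=O)N(Cc2ccccc2)Cc2ccccc2)cc1C` gives 0.16 ug/mL; compound 3 `Cc1cc(C)c(NC(=O)N(Cc2ccccc2)Cc2ccccc2)c(C)c1` gives 1.34 ug/mL.

Compound 3 thus has the highest number of the three, making it the weakest inhibitor in this set. Among the compounds with values here, the only measured step, an 8.4-fold higher number from compound 2 to compound 3 (0.92 log units; beyond the scatter), shows that rearranging the methyl groups on this ring alone shifts the number well beyond the scatter. Compound 4 `O=C(Nc1cc(Cl)cc(Cl)c1)N(Cc1ccccc1)Cc1ccccc1` differs from compound 3 by 3,5-dichlorophenyl in place of 2,4,6-trimethylphenyl on an amide-type nitrogen. Within the data shown here, no measured step covers an exchange of this kind, so the size of the effect is uncertain; that single step only shows the substitution pattern on this ring matters. A modestly higher number is therefore expected for compound 4, a 1.5-fold higher number from compound 3 to compound 4 (0.17 log units; within the scatter). The estimate for compound 4 is 2 ug/mL, within 0.5 ug/mL to 8 ug/mL.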

Compound 4, half-maximal inhibitory concentration: 1.53 ug/mL
The estimate for compound 4 lay 1.3-fold (0.12 log units) above the measured number; measured number inside the range.
By their numbers in this assay, from the lowest: compounds 2 and 1 (each within the scatter of the next); then compounds 3 and 4 (each within the scatter of the next).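

In this assay, 3,5-dichlorophenyl in place of 2,4,6-trimethylphenyl gives a 1.1-fold higher number from compound 3 to compound 4 (0.06 log units; within the scatter) and so leaves the number unchanged within the scatter, even though chlorine replaces methyl and the ring pattern differs. The same group set against 2,4,5-trimethylphenyl gives a 9.6-fold higher number from compound 2 to compound 4 (0.98 log units; beyond the scatter) and so, among these three rings, only the ring of compound 2 stands apart. No measurement at hand bears on why these rings compare as they do. Going by these compounds, whether a ring carrying methoxy, trifluoromethyl or nitrile on the amide-type nitrogen would match compound 2 or compound 4 stays open. So does the effect of a carboxylic acid or an amine on that ring.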